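Substituent on the aromatic nitrogen: compound 3 to compound 4

The source may report more compounds than this note shows. Statements on the series, on what has been measured and on what is new or still open speak of the compounds shown alone.

Measured so far in a functional assay on HT-29 cells (Homo sapiens) for inhibition, read by luminescence and CellTiter-Glo, with a stated time of 24 h (a higher number here means that more compound is needed for the effect, a lower number that less compound is needed), for this series:
- Compound 1 `CCCCCn1nc(C(=O)N[C@H]2COc3ccccc3N(C)C2=S)nc1Cc1ccccc1` (805 nM)
- Compound 2 `CN1C(=S)[C@@H](NC(=O)c2nc(Cc3ccccc3)n(CCCCCC#N)n2)COc2ccccc21` (3830 nM)
- Compound 3 `CN1C(=S)[C@@H](NC(=O)c2nc(Cc3ccccc3)n(C3CCCCCC3)n2)COc2ccccc21` (5530 nM)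

Compound 3 belongs to the upper end of these numbers. Its nearest step is a 1.4-fold higher number from compound 2 to compound 3 (0.16 log units; within the scatter) and its furthest is a 6.9-fold higher number from compound 1 to compound 3 (0.84 log units; beyond the scatter) on the same scale. Compound 4 `CN1C(=S)[C@@H](NC(=O)c2nc(Cc3ccccc3)n(CC3CCOCC3)n2)COc2ccccc21` carries (oxan-4-yl)methyl in place of cycloheptyl on an aromatic nitrogen and keeps the shared core.

All three measured steps concern this same nitrogen substituent. Two are modest, namely a 4.8-fold higher number from compound 1 to compound 2 (0.68 log units; beyond the scatter) and the step to cycloheptyl already given. The exchange of 5-cyanopentyl for cycloheptyl stays within the scatter. Only compound 1 (805 nM) stands apart, while compound 2 (3830 nM) carries a chain with a nitrile and still sits with compound 3. For the measured compounds named here, no measured compound carries (oxan-4-yl)methyl, so this reading is weakly supported and the range must stay wide.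

In this assay the expected result is a 1.4-fold lower number from compound 3 to compound 4 (0.14 log units; within the scatter) and no step beyond the scatter is expected. The estimated value for compound 4 is 4000 nM with an expected range from 1300 nM to 12000 nM in these notes.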

Compound 4, half-maximal effective concentration: 6310 nM
Compound 4: middle estimate off by 1.6-fold (0.20 log units), on the low side; low and high end bracket the measured number.
By their numbers in this assay, from the lowest: compound 1; then compounds 2, 3 and 4 (each within the scatter of the next).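

In this assay, (oxan-4-yl)methyl sits with the two other large substituents, as shown by a 1.1-fold higher number from compound 3 to compound 4 (0.06 log units; within the scatter) and by a 1.6-fold higher number from compound 2 to compound 4 (0.22 log units; within the scatter), while a 7.8-fold higher number from compound 1 to compound 4 (0.89 log units; beyond the scatter) is a modest step beyond the scatter and leaves pentyl as the only substituent apart from this group. The exchange of a seven-membered ring of carbon only for a six-membered ring with one oxygen, carried on a saturated chain carbon and with the same count of heavy atoms, therefore stays within the scatter, and this group of compounds now holds a nitrile chain, a carbocycle and an oxygen-containing ring. No evidence on the reason for this reading is available.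

As far as these compounds go, whether an unbranched chain shorter or longer than pentyl keeps the number that compound 1 gives, 805 nM, remains open. Also open, from the compounds shown here alone, is whether a pentyl chain ending in an amine or a carboxylic acid would sit with compound 1 or with compounds 2, 3 and 4.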